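Methyl in place of fluoro in compound 3

The compounds below may be only part of what the source reports. "The series", "measured", "known", "first", "only" and "open" are said of these compounds alone.

Measured in an ADME assay on Vero 76 cells (Chlorocebus sabaeus) for cytotoxicity, read by crystal violet staining, with a stated time of 96 h; a higher number here means that more compound is tolerated, a lower number that less compound is tolerated:
compound 1 `O=C(NC(=S)Nc1cccc(C(F)(F)F)c1)c1ccccc1`: > 100000 nM
compound 2 `Fc1ccc(NC(=S)Nc2cccc(C(F)(F)F)c2)cc1Cl`: 20000 nM

The entry for compound 1, > 100000 nM, is a limit of the assay and not a number.

In this assay, going by the values given here, compound 2 gives 20000 nM, the only actual number so far. Among the compounds with values here, no pair of measured compounds differing in one place is available, so the data offer no direct precedent for the next change.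

Compound 3 `Cc1ccc(NC(=S)Nc2cccc(C(F)(F)F)c2)cc1Cl` carries methyl in place of fluoro on an aromatic carbon, ortho to a chloro group and para to a large group: methyl in place of fluoro on an aromatic carbon. For this single exchange, no shift beyond the usual scatter is expected in this assay, in either direction, so the expectation stays anchored on compound 2 at 20000 nM. The estimated step is a 1.1-fold lower number from compound 2 to compound 3 (0.05 log units; within the scatter). For compound 3 the expected value is 18000 nM, with an estimated range of 7000 nM to 50000 nM.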

Compound 3, half-maximal cytotoxic concentration: 20000 nM
Compound 3: the middle estimate sits 1.1-fold (0.05 log units) below what was measured; the measured number falls inside the stated range.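

In this assay, methyl in place of fluoro on the aromatic carbon ortho to a chloro group and para to a large group gives no change at the digits printed from compound 2 to compound 3 (within the scatter). Going by these compounds alone, this is the first comparison of compounds that differ in one place, and it shows that, at this position, this exchange leaves the cytotoxic concentration unmoved within the scatter. Compound 1 alone carries a limit of the assay, and it provides no step to set beside this one: the limit of > 100000 nM in this assay, at which 1 of the 3 values shown sits.

On these data alone, whether an amine, a carboxylic acid or a longer chain at this position would shift the number remains open. Within the data shown here, the single pair also leaves open whether the same exchange would behave alike with a hydrogen in place of the chloro group.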